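Moving the thiazole link on compound 3

The compounds below may be only part of what the source reports. "The series", "measured", "known", "first", "only" and "open" are said of these compounds alone.

Values so far in a functional assay on MCF7 cells (Homo sapiens) for antiproliferative activity, read by CellTiter-Glo, with a stated time of 5 days; a higher number here means a weaker inhibitor, a lower number a stronger inhibitor
- compound 1 `CC/C(=C(/c1ccc(/C=C/C(=O)O)cc1)c1ccc2c(cnn2C)c1)c1ccc(F)cc1Cl` gives 81 nM
- compound 2 `CC/C(=C(/c1ccc(/C=C/C(=O)O)cc1)c1ccc(-c2cscn2)cc1)c1ccccc1` gives 120 nM
- compound 3 `CC/C(=C(/c1ccc(/C=C/C(=O)O)cc1)c1ccc(-c2cncs2)cc1)c1ccccc1` gives 31 nM

Compound 3 stands lowest of these three at 31 nM while compound 4 `CC/C(=C(/c1ccc(/C=C/C(=O)O)cc1)c1ccc(-c2nccs2)cc1)c1ccccc1` remains unmeasured. Compound 4 carries 1,3-thiazol-2-yl in place of 1,3-thiazol-5-yl on an aromatic carbon with the same atoms joined differently. Among the compounds with values here, the only measured step that bears on this is a 3.9-fold lower number from compound 2 to compound 3 (0.59 log units; beyond the scatter) for 1,3-thiazol-5-yl in place of 1,3-thiazol-4-yl. Within the data shown here, no measurement yet covers 1,3-thiazol-2-yl itself. Compound 3 already sits lowest, so a modest move to a higher number in this assay is expected, no larger than that measured step. The expected step is a 2.3-fold higher number from compound 3 to compound 4 (0.35 log units; beyond the scatter) on this estimate. For compound 4 the estimate is 70 nM with an expected range of 25 nM to 200 nM as the likely span.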

Compound 4, half-maximal inhibitory concentration: 290 nM
Compound 4: middle estimate off by 4.1-fold (0.62 log units), on the low side; the measured number lies above the stated range.
By their numbers in this assay, from the lowest: compound 3; then compounds 1 and 2 (each within the scatter of the next); then compound 4.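

In this assay, moving the link to 1,3-thiazol-2-yl gives a 9.4-fold higher number from compound 3 to compound 4 (0.97 log units; beyond the scatter) and is the largest step yet seen at this position. It also gives a 2.4-fold higher number from compound 2 to compound 4 (0.38 log units; beyond the scatter) and so completes the order of the three thiazoles, with 1,3-thiazol-5-yl lowest, 1,3-thiazol-4-yl next and 1,3-thiazol-2-yl highest, each step beyond the scatter. Since the two groups have the same atoms, the way the ring is joined alone separates these numbers. Going by these compounds, whether a 1,3-oxazol-5-yl group would follow the 1,3-thiazol-5-yl group remains open. On these data alone, what underlies this order also stays open, as no supporting data bear on it.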